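The compounds below may be only part of what the source reports. "The series", "measured", "known", "first", "only" and "open" are said of these compounds alone.

In an ADME assay on L6 cells (Rattus norvegicus) for cytotoxicity (a lower number here means a stronger inhibitor, a higher number a weaker inhibitor), compound 2 (`O=C(NCCCN1CCN(CCCNc2ccnc3cc(Cl)ccc23)CC1)c1cccc(OC(F)(F)F)c1`) gives 8500 nM and stands highest of the three numbers, beyond the scatter from both others. Compound 3 (`O=C(NCCCN1CCN(CCCNc2ccnc3cc(Cl)ccc23)CC1)c1ccccc1C(=O)c1ccccc1`) gives 3200 nM on the same read-out. Compound 1 (`O=C(NCCCN1CCN(CCCNc2ccnc3cc(Cl)ccc23)CC1)c1ccc(Oc2ccccc2)cc1`) gives 1400 nM on it too. Compound 4 (`O=C(CCCc1ccccc1)NCCCN1CCN(CCCNc2ccnc3cc(Cl)ccc23)CC1`) carries 3-phenylpropyl in place of 3-(trifluoromethoxy)phenyl on a carbonyl carbon. Going by the values given here, no measured pair isolates this change, so the expectation rests only on the spread of the three numbers. Compound 2 at 8500 nM tops that spread, so a modest move to a lower number is expected. The estimated change is a 2.1-fold lower number from compound 2 to compound 4 (0.33 log units; beyond the scatter) in size. For compound 4 the estimated value is 4000 nM with an expected range from 1500 nM to 10000 nM as the working bounds.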

Compound 4, half-maximal inhibitory concentration: 11000 nM
For compound 4 the middle estimate is 2.8-fold (0.44 log units) below the measured one; measured number outside the range, above it.
By their numbers in this assay, from the lowest: compound 1; then compound 3; then compounds 2 and 4 (each within the scatter of the next).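

In this assay the exchange of 3-(trifluoromethoxy)phenyl for 3-phenylpropyl on a carbonyl carbon gives a 1.3-fold higher number from compound 2 to compound 4 (0.11 log units; within the scatter) and so makes no difference that can be read at this position. The oxygen, the fluorines and the hydrogen-bond acceptor of the group in compound 2 are absent from the group in compound 4, yet the two numbers stay within the scatter of each other. No measured evidence bears on this result. Open, going by these compounds, is whether an amine or a carboxylic acid on this carbonyl carbon would move the number. On these data alone, a longer chain ending in phenyl also remains untested here.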